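The source may report more compounds than this note shows. Statements on the series, on what has been measured and on what is new or still open speak of the compounds shown alone.

Compound 1 `Nc1ccc(/C=C/C(=O)c2ccccc2)cc1` and compound 3 `Nc1ccc(C(=O)/C=C/c2ccccc2)cc1` share the same atoms joined differently; the difference between the two cores is not broken down here. Within the data shown here, in a functional assay on L1210 cells (Mus musculus) for antiproliferative activity, with a stated time of 48 h (a lower number here means a stronger inhibitor, a higher number a weaker inhibitor), compound 1 gives 88000 nM, while compound 3 gives 14000 nM, the lowest number of the three measured so far. Compound 2 `COc1cccc(C(=O)/C=C/c2ccc(N)cc2)c1` carries one change on the core of compound 1, (methoxy in place of hydrogen on an aromatic carbon), and in this assay compound 2 gives 38000 nM, a step of a 2.3-fold lower number from compound 1 to compound 2 (0.36 log units; beyond the scatter). Compound 4 `COc1cccc(/C=C/C(=O)c2ccc(N)cc2)c1` is made from compound 3 by the same change, (methoxy in place of hydrogen on an aromatic carbon). The step from compound 3 to compound 4 in this assay is expected to be about as large, a 2.2-fold lower number from compound 3 to compound 4 (0.33 log units; beyond the scatter), resting only on the step from compound 1 to compound 2 a 2.3-fold lower number from compound 1 to compound 2 (0.36 log units; beyond the scatter) seen once. Compound 4 is therefore estimated at 6500 nM, likely between 2500 nM and 16000 nM.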

Compound 4, half-maximal inhibitory concentration: 22000 nM
The estimate for compound 4 lay 3.4-fold (0.53 log units) below the measured number; the whole stated range lies below it.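

Placed on the core of compound 3, methoxy in place of hydrogen on an aromatic carbon gives a 1.6-fold higher number from compound 3 to compound 4 (0.20 log units; within the scatter) in this assay, so on this core its effect cannot be told apart from repeat-measurement noise. Set beside the earlier step, the same change does not carry over equally between the two cores: the same change on two cores in this assay, a 2.3-fold lower number (0.36 log units; beyond the scatter) from compound 1 to compound 2 and a 1.6-fold higher number (0.20 log units; within the scatter) from compound 3 to compound 4, 3.6-fold (0.56 log units) apart, beyond the scatter of two such steps. Among these compounds, with only one pair per core, this shows that the step on one core was a poor guide to the step on the other, but not why they differ or how the change would behave on a further core.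

Still open, from the compounds shown here alone, is whether a different group on that aromatic carbon, such as ethoxy, fluorine or a hydroxyl, would give matching steps on both cores.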